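The compounds below may be only part of what the source reports. "The series", "measured", "known", "first", "only" and "open" are said of these compounds alone.

Working notes on the ureas built around the shared core of compound 1, `C[C@@H](NC(=O)Nc1ccccc1F)c1ccccc1`. Among the measured compounds shown here, in an ADME assay on the whole organism with Oryza sativa as the target, tested at 10 uM (a higher number here means a weaker effect of the compound at the concentration tested, a lower number a stronger effect), compound 1 gives 77%, the lowest of the three numbers measured so far. Compound 2, `C[C@@H](NC(=O)Nc1ccccc1Cl)c1ccccc1`, gives 93%, and compound 3, `C[C@@H](NC(=O)Nc1ccccc1Br)c1ccccc1`, gives 94%. The steps of a number 16 percentage points higher from compound 1 to compound 2 (beyond the scatter) and a number 17 percentage points higher from compound 1 to compound 3 (beyond the scatter) are both beyond the scatter, whereas a number 1 percentage points higher from compound 2 to compound 3 (within the scatter) is within it.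

Compound 4, `C[C@@H](NC(=O)Nc1cccc(F)c1F)c1ccccc1`, keeps the fluoro of compound 1 and adds a second one: fluoro in place of hydrogen on an aromatic carbon. For the measured compounds named here, no measured step introduces a second substituent on this ring; the two steps that leave compound 1 replace the fluoro with chloro or bromo rather than adding to it, so they bear on compound 4 only loosely. Since both of those steps raised the number by a modest amount, a small rise or no step beyond the scatter is expected here, and the step of a number 5 percentage points higher from compound 1 to compound 4 (within the scatter) is taken as the estimate. For compound 4 the expected value in this assay is therefore 82%, within an estimated range of 65% to 96%.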

Compound 4, a percentage reported as activity, at one concentration (the size of the read-out at that concentration, not a potency): 90%
Compound 4: middle estimate off by 8 percentage points, on the low side; measured number inside the range.
By their numbers in this assay, from the lowest: compound 1; then compounds 4, 2 and 3 (each within the scatter of the next).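

Adding fluoro in place of hydrogen on an aromatic carbon, ortho to a fluoro group and meta to a large group, gives a number 13 percentage points higher from compound 1 to compound 4 (beyond the scatter) in this assay, so the number also responds at a ring carbon that carries hydrogen in compounds 1, 2 and 3. The fluoro of compound 1 is kept in compound 4, so a rise beyond the scatter does not require replacing that fluoro with chloro or bromo; adding a second halogen also moves the number towards a weaker effect at the concentration tested. No measured information accounts for this rise.

The compounds shown leave open whether chloro, methoxy or an amine on that carbon would move the number as fluoro does. They also leave open whether fluoro on another carbon of this ring would give a similar step.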